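The source may report more compounds than this note shows. Statements on the series, on what has been measured and on what is new or still open speak of the compounds shown alone.

Compound 1 `CC1=CC[C@@H]([C@@](C)(O)CCCC(C)(C)NC(=S)NN)CC1`: > 100000 nM (a limit)
Compound 2 `CC1=CC[C@@H]([C@@](C)(O)CCCC(C)(C)NC(=S)N/N=C\c2ccc([N+](=O)[O-])cc2)CC1`: > 100000 nM (a limit)

In a functional assay on MCF7 cells (Homo sapiens) for cytotoxicity, read by sulforhodamine B assay (a higher number here means that more compound is tolerated, a lower number that less compound is tolerated), compound 2 gives no number, only the limit > 100000 nM. Compound 1 also gives only a limit, and the two compounds share it: the limit of > 100000 nM in this assay, at which 2 of the 2 values shown sit. Compound 3 `CC1=CC[C@@H]([C@@](C)(O)CCCC(C)(C)NC(=S)N/N=C\c2ccc(Cl)cc2)CC1` has chloro in place of nitro on an aromatic carbon, para to a large group: chloro in place of nitro on an aromatic carbon. For the measured compounds named here, no measured step shows what such a change does, so none beyond the scatter is expected in this assay. The expected change is an at least 1.1-fold lower number from compound 2 to compound 3 (0.04 log units; that floor lies within the scatter). Compound 3 is estimated at 90000 nM, with an expected range of 30000 nM to 150000 nM.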

Compound 3, concentration lethal to 50% of the cells: 44300 nM
Compound 3: the middle estimate sits 2.0-fold (0.31 log units) above what was measured; low and high end bracket the measured number.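

Compound 3 is the only compound shown that gives a number rather than a limit in this assay, while the other two share a limit: the limit of > 100000 nM in this assay, at which 2 of the 3 values shown sit. Chloro in place of nitro on an aromatic carbon, para to a large group, gives an at least 2.2-fold lower number from compound 2 to compound 3 (0.35 log units; beyond the scatter), so this position does bear on the read-out. The 4-chlorophenyl-bearing end, set against the open nitrogen end, gives an at least 2.2-fold lower number from compound 1 to compound 3 (0.35 log units; beyond the scatter).

Going by these compounds, both steps start from a limit, so their full size stays open. On these data alone, whether bromo, methoxy or an amine at this position would lower the number further also remains open.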